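A few compounds are considered here, and "the series" means these few. Any claim that something is new, unique, unknown or untested is made for them only; others in the source may bear on it.

Measured so far in a toxicity assay on the whole organism (J774 cells) for cytotoxicity, with Mus musculus as the target, read by MTT assay, with a stated time of 24 h, tested at 10 uM; on this read-out lower numbers stand for a stronger effect and higher numbers for a weaker effect at the one concentration tested:

compound 1, `CCCCCCCCCO[C@@H]1[C@@H](N)[C@@H](OCC(O)CO)O[C@H](CN)[C@H]1OCCCCCCCCC`: 89.7%
compound 2, `C=CCO[C@H]1O[C@H](CN)[C@@H](OCCCc2ccc3ccccc3c2)[C@H](OCCCc2ccc3ccccc3c2)[C@H]1N`: 105%
compound 3, `NC[C@H]1O[C@H](O[C@H]2[C@H](O)[C@@H](O)[C@H](N)C[C@@H]2N)[C@H](N)[C@@H](OCc2ccc3ccccc3c2)[C@@H]1OCc1ccc2ccccc2c1`: 79.1%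

Compound 1 stands second highest of the three numbers in this assay. Its nearest neighbour is compound 3, whose number is lower by a margin beyond the scatter; the furthest is compound 2, whose number is higher, again beyond the scatter. Among the measured compounds shown here, all three numbers sit toward the weaker end of the read-out at the one concentration tested, and no pair among them differs in only one place, so no single-change step has been measured.

The next compound, compound 4, `CCCCCCCCCO[C@@H]1[C@@H](N)[C@@H](OC[C@H](O)CN)O[C@H](CN)[C@H]1OCCCCCCCCC`, keeps the core of compound 1 and differs from it in one place: 2-amino-1-hydroxyethyl in place of 1,2-dihydroxyethyl on a saturated chain carbon bound to an oxygen on a saturated carbon.

For the measured compounds named here, with no measured single-change step to anchor the size of this change, the expectation rests on the narrow band in which the three measured numbers fall. The expected step is a number 4.7 percentage points lower from compound 1 to compound 4 (within the scatter), small, tending toward a somewhat lower number, and not clearly beyond the scatter. Compound 4 is accordingly estimated at 85% in this assay, with a range from 65% to 105%.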

Compound 4, a percentage reported as activity, at one concentration (the size of the read-out at that concentration, not a potency): 88%
Estimate against measurement, compound 4: 3 percentage points below; the range from low to high includes it.
By their numbers in this assay, from the lowest: compounds 3, 4 and 1 (each within the scatter of the next, the first and the last beyond it); then compound 2.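

In this assay, among the compounds shown here, 2-amino-1-hydroxyethyl in place of 1,2-dihydroxyethyl on a saturated chain carbon bound to an oxygen on a saturated carbon gives a number 1.7 percentage points lower from compound 1 to compound 4 (within the scatter) and is the first single-change step. This position on the core of compound 1 therefore accepts one nitrogen in place of one oxygen, along with a defined stereocentre, without a separation from compound 1 that exceeds the scatter, while the counts of heavy atoms, hydrogen-bond donors and hydrogen-bond acceptors stay the same in both groups. Nothing on hand accounts for this result.

One step at one concentration gives no picture of how far this position can be changed before the read-out moves beyond the scatter. On these data alone, it remains open whether a carboxylic acid, a guanidine or a longer chain ending in an amine at this position would stay as close to compound 1, and whether the opposite configuration at the stereocentre of 2-amino-1-hydroxyethyl would do the same.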